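The compounds below may be only part of what the source reports. "The series", "measured", "known", "first", "only" and "open" are said of these compounds alone.

In a functional assay on L1210 cells (Mus musculus) for antiproliferative activity, read by cell counting, with a stated time of 48 h (a higher number here means a weaker inhibitor, a lower number a stronger inhibitor), compound 1 `C#C[C@@]1(O)[C@@H](CO)O[C@@H](n2cc(Cl)c3c(Cl)ccnc32)[C@@H]1O` gives 75000 nM, the second highest of three numbers. Compound 2 `C#C[C@@]1(O)[C@@H](CO)O[C@@H](n2cc(Br)c3c(Cl)ccnc32)[C@@H]1O` gives 30000 nM and compound 3 `C#C[C@@]1(O)[C@@H](CO)O[C@@H](n2ccc3c(Cl)ccnc32)[C@@H]1O` gives 197000 nM. Compound 4 `C#C[C@@]1(O)[C@@H](CO)O[C@@H](n2cc(Cl)c3c(N)ccnc32)[C@@H]1O` keeps the core of compound 1 and differs by amino in place of chloro on an aromatic carbon, opposite the ring nitrogen.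

For the measured compounds named here, no measured step touches this site. All three exchange halogen or hydrogen on a different aromatic carbon, and the chloro that leaves here is present throughout compounds 1, 2 and 3. Going by the values given here, they show only that a single aromatic exchange elsewhere moved the number by modest amounts: a 2.5-fold lower number from compound 1 to compound 2 (0.40 log units; beyond the scatter), a 2.6-fold higher number from compound 1 to compound 3 (0.42 log units; beyond the scatter) and, the largest, a 6.6-fold higher number from compound 2 to compound 3 (0.82 log units; beyond the scatter). They therefore give only a loose guide to size and none to direction. The new group differs in kind from a halogen, so a lower number is expected, though with little support from the data, and the step may exceed those seen so far. The expected change is a 9.4-fold lower number from compound 1 to compound 4 (0.97 log units; beyond the scatter). Compound 4 is estimated at 8000 nM, with an expected range from 500 nM to 90000 nM.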

Compound 4, half-maximal inhibitory concentration: 980 nM
Beside the measured number, compound 4's estimate is 8.2-fold (0.91 log units) above it, and the stated range covers the measured number.
By their numbers in this assay, from the lowest: compound 4; then compound 2; then compound 1; then compound 3.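

For the compounds shown here, the position opposite the ring nitrogen proves far more responsive than the earlier compounds could indicate: in this assay, amino in place of chloro gives a 77-fold lower number from compound 1 to compound 4 (1.88 log units; beyond the scatter), a larger step than the biggest exchange on the other aromatic carbon, a 6.6-fold higher number from compound 2 to compound 3 (0.82 log units; beyond the scatter). The change swaps one heavy atom for one heavy atom, yet it replaces a group with no hydrogen-bond donors or acceptors by one that has a donor and an acceptor. Nothing available accounts for the size of this step.

The compounds shown leave open whether a methylamino, a dimethylamino or a hydroxyl group at this position would give a similar step. They also leave open whether the amino step would hold with the bromo of compound 2 or the hydrogen of compound 3 on the other aromatic carbon.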